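The source may hold more compounds than are shown below. What is called first, only, known or untested is meant among the compounds shown, and "the series" means these compounds.

Working notes on the series. The shared core carries an acylamino group that is varied: compound 1 `CC1(C)Cc2c(sc(NC(=O)c3ccccc3O)c2C(N)=O)CO1` bears a hydroxyphenyl carbonyl, compound 2 `CC1(C)Cc2c(sc(NC(=O)[C@@H](O)C(C)(C)C)c2C(N)=O)C(C)(C)O1` and compound 3 `CC1(C)Cc2c(sc(NC(=O)[C@H](O)C(C)(C)C)c2C(N)=O)C(C)(C)O1` bear a 1-hydroxy-2,2-dimethylpropyl carbonyl in opposite configurations. In an assay on cells for positive allosteric modulation of Cystic fibrosis transmembrane conductance regulator variant G551D (Homo sapiens), with stated times of 10 min and 2 min, in the presence of a further agent that is not named here (on this read-out lower numbers stand for an effect already at smaller amounts and higher numbers for an effect only at larger amounts of compound), compound 1 gives 490 nM and compound 2 gives 421 nM, the two within the scatter of one another; compound 3 gives 7780 nM. Compound 2 has the lowest number of the three, though not separated from compound 1. The step of an 18-fold higher number from compound 2 to compound 3 (1.27 log units; beyond the scatter) is the only measured one and rests on (the fact that compounds 2 and 3 differ only in the configuration as drawn).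

Compound 4 `Cc1n[nH]c(C(=O)Nc2sc3c(c2C(N)=O)CC(C)(C)OC3(C)C)c1Cl` differs from compound 2 by a group of 7 heavy atoms (4 carbon, 2 nitrogen, 1 chlorine; one five-membered aromatic ring with 2 hetero atoms) in place of a group of 6 heavy atoms (5 carbon, 1 oxygen; no ring), on a carbonyl carbon. The stereocentre that drove the step from compound 2 to compound 3 no longer exists, so that step gives no direction here. Compound 1 shows that a ring-bearing acyl group gives a number close to compound 2, so an expected change of a 1.4-fold higher number from compound 2 to compound 4 (0.15 log units; within the scatter) within the scatter is the estimate. Compound 4 is expected near 600 nM, between 150 nM and 2500 nM.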

Compound 4, half-maximal effective concentration: 199 nM
Compound 4: middle estimate off by 3.0-fold (0.48 log units), on the high side; low and high end bracket the measured number.
By their numbers in this assay, from the lowest: compound 4; then compounds 2 and 1 (each within the scatter of the next); then compound 3.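

On a carbonyl carbon whose other neighbours are the amide-type nitrogen, a low number in this assay does not depend on the stereocentre of 1-hydroxy-2,2-dimethylpropyl: the five-membered aromatic ring with 2 hetero atoms gives a 2.1-fold lower number from compound 2 to compound 4 (0.33 log units; beyond the scatter). Set against the other configuration, the same exchange gives a 39-fold lower number from compound 3 to compound 4 (1.59 log units; beyond the scatter). Nothing measured here accounts for either step. The compounds shown leave open what the chlorine of compound 4 contributes, and how an amine or a carboxylic acid in its place would read.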